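The source may hold more compounds than are shown below. What is called first, only, known or untested is meant among the compounds shown, and "the series" means these compounds.

Working notes on the series. In an assay on CHO cells for displacement of a labelled ligand from adenosine receptor A1 (Homo sapiens), read by scintillation counting, with a stated time of 90 min, in the presence of a further agent that is not named here (a higher number here means a weaker inhibitor, a lower number a stronger inhibitor), compound 1 `CCCn1c(=O)[nH]c2nc(-c3ccc(S(=O)(=O)N4CCN(c5ccc(Cl)cc5F)CC4)cc3)[nH]c2c1=O` returns only the assay limit, > 1000 nM. Compound 2 `CCCn1c(=O)[nH]c2nc(-c3ccc(S(=O)(=O)N4CCN(c5ccc(I)cc5)CC4)cc3)[nH]c2c1=O` also returns only the limit in this assay, > 1000 nM. The step that the two limits leave unreadable from compound 1 to compound 2 cannot be read, since both values sit at the limit of > 1000 nM in this assay, at which 2 of the 2 values shown sit. Compound 3 `CCCn1c(=O)[nH]c2nc(-c3ccc(S(=O)(=O)N4CCN(c5ccccc5Cl)CC4)cc3)[nH]c2c1=O` differs from compound 2 by 2-chlorophenyl in place of 4-iodophenyl on an amine nitrogen in a ring. For the measured compounds named here, no measured step gives a readable size or direction, so nothing beyond the scatter is expected for this change. Compound 3 is expected to remain at the limit, estimated at 3000 nM within 800 nM to 20000 nM. The implied step that the limit leaves unreadable from compound 2 to compound 3 is expected to be small.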

Compound 3, inhibition constant: > 1000 nM
Compound 3 ended at the assay's limit; the forecaster's own chance of this, stated with the estimate: 75%; the middle value lies beyond the limit too.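

No new step can be read from compound 2 to compound 3 or from compound 1 to compound 3, since all values in this assay are limits: the limit of > 1000 nM in this assay, at which 3 of the 3 values shown sit. The compounds shown leave open whether these phenyl groups on the amine nitrogen in the ring differ at all in inhibition constant.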